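A Trifluoromethylphenyl Swap on a Level Pair

The compounds below may be only part of what the source reports. "The series", "measured", "known", "first", "only" and "open" are said of these compounds alone.

In a functional assay on MDA-MB-231 cells (Homo sapiens) for cytotoxicity, read by MTT assay, with a stated time of 48 h (on this read-out lower numbers stand for stronger inhibition and higher numbers for weaker inhibition), compound 1 `COc1cc(C2=NOC(COc3ccc(-c4nnnn4-c4cc(OC)c(OC)c(OC)c4)cc3N)C2)ccc1O` gives 3620 nM and compound 2 `COc1ccc(C2=NOC(COc3ccc(-c4nnnn4-c4cc(OC)c(OC)c(OC)c4)cc3N)C2)cc1[N+](=O)[O-]` gives 3560 nM. Among the measured compounds shown here, compound 2 therefore stands level with compound 1, the only other compound measured so far, and the two numbers cannot be told apart.

Compound 3 `COc1cc(-n2nnnc2-c2ccc(OCC3CC(c4ccc(C(F)(F)F)cc4)=NO3)c(N)c2)cc(OC)c1OC` keeps the shared core of compound 2 and changes one group: 4-(trifluoromethyl)phenyl in place of 4-methoxy-3-nitrophenyl on a carbon with a double bond to nitrogen. For the measured compounds named here, one measured step bears on this change, since it altered the same place on a carbon with a double bond to nitrogen. That step is a 1.0-fold lower number from compound 1 to compound 2 (0.01 log units; within the scatter), and it replaced 4-hydroxy-3-methoxyphenyl with 4-methoxy-3-nitrophenyl. Going by the values given here, its size lies within the scatter, so the only exchange seen at this place left the number in this assay where it was. Among the compounds with values here, one step is thin evidence, however, and no measured compound carries a trifluoromethyl group, so the range must stay wide.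

No shift beyond the scatter is expected, and the estimated change is a 1.2-fold lower number from compound 2 to compound 3 (0.07 log units; within the scatter). For compound 3 the expected value is 3000 nM, with an estimated range from 1000 nM to 9000 nM.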

Compound 3, half-maximal inhibitory concentration: 1750 nM
Beside the measured number, compound 3's estimate is 1.7-fold (0.23 log units) above it; the range from low to high includes it.
By their numbers in this assay, from the lowest: compound 3; then compounds 2 and 1 (each within the scatter of the next).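

Among the compounds shown here, the single earlier step at this place, between compound 1 and compound 2, stayed within the scatter and could have suggested that the number in this assay does not respond to changes here. Compound 3 shows otherwise: placing 4-(trifluoromethyl)phenyl on the carbon with a double bond to nitrogen gives a 2.0-fold lower number from compound 2 to compound 3 (0.31 log units; beyond the scatter), and the comparison with the 4-hydroxy-3-methoxyphenyl compound gives a 2.1-fold lower number from compound 1 to compound 3 (0.32 log units; beyond the scatter), so the move is modest but beyond the scatter on both counts, and two different starting groups lead to nearly the same result. Nothing among the data shown explains why this exchange lowers the number.

Open, as far as these compounds go, is whether the trifluoromethyl group itself matters, or whether simply having none of the methoxy, hydroxy or nitro groups on the ring is enough, a question that an unsubstituted phenyl group at this place would help settle. Also open, from the compounds shown here alone, is how a 4-chlorophenyl or a 4-aminophenyl group here would compare with 4-(trifluoromethyl)phenyl on the same shared core.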